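The compounds below may be only part of what the source reports. "The series", "measured", "known", "first", "only" and "open" are said of these compounds alone.

Measured so far:
- compound 1 `COc1cc(Cl)cc(-c2nn(-c3cccc(NC(=O)Nc4ccc(Cl)c(C(F)(F)F)c4)c3)cc2-c2ccncc2)c1`: -79%
- compound 2 `COc1cc(Cl)cc(-c2nn(-c3cccc(NC(=O)Nc4cc(C(F)(F)F)cc(C(F)(F)F)c4)c3)cc2-c2ccncc2)c1`: -68%
- compound 3 `COc1cc(Cl)cc(-c2nn(-c3cccc(NC(=O)Nc4ccc(Cl)c(Cl)c4)c3)cc2-c2ccncc2)c1`: -100%

In a functional assay on COLO 205 cells (Homo sapiens) for inhibition, read by sulforhodamine B assay, with a stated time of 48 h, tested at 100 uM (on this read-out lower numbers stand for a stronger effect and higher numbers for a weaker effect at the one concentration tested), compound 3 gives the lowest of the three numbers, that is the strongest effect seen. Its nearest neighbour is compound 1, whose value in this assay stands higher, and compound 2 lies furthest, both beyond the scatter. Among the measured compounds shown here, the one single-point step recorded is a number 21 percentage points lower from compound 1 to compound 3 (beyond the scatter).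

Compound 4 `COc1cc(Cl)cc(-c2nn(-c3cccc(NC(=O)Nc4cccc(C(F)(F)F)c4)c3)cc2-c2ccncc2)c1` is the next compound. It differs from compound 3 as follows: 3-(trifluoromethyl)phenyl in place of 3,4-dichlorophenyl on an amide-type nitrogen

For the measured compounds named here, no measured step matches this change exactly. Going by the values given here, the only step that bears on it runs the other way in kind: a number 21 percentage points lower from compound 1 to compound 3 (beyond the scatter), where a chloro in place of a trifluoromethyl lowered the number. Compound 4 reverses that exchange and at the same time drops the second chlorine of the 3,4-dichlorophenyl, so a move back towards the region of compound 1 and compound 2, i.e. a weaker effect than compound 3, is the expectation in this assay, with a number 28 percentage points higher from compound 3 to compound 4 (beyond the scatter) as the expected step. The estimate for compound 4 is -72%, expected to fall between -95% and -45%.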

Compound 4, a percentage reported as activity, at one concentration (the size of the read-out at that concentration, not a potency): -95%
Compound 4: the middle estimate sits 23 percentage points above what was measured; low and high end bracket the measured number.
By their numbers in this assay, from the lowest: compounds 3 and 4 (each within the scatter of the next); then compound 1; then compound 2.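

In this assay, 3-(trifluoromethyl)phenyl in place of 3,4-dichlorophenyl on the amide-type nitrogen gives a number 5 percentage points higher from compound 3 to compound 4 (within the scatter) and so leaves the read-out unresolved, which shows that this position tolerates this exchange of aryl groups, although the earlier chloro-for-trifluoromethyl step a number 21 percentage points lower from compound 1 to compound 3 (beyond the scatter) had suggested otherwise. Among the compounds shown here, compound 4 also adds two comparisons that the earlier compounds could not give: hydrogen in place of trifluoromethyl gives a number 27 percentage points lower from compound 2 to compound 4 (beyond the scatter) and hydrogen in place of chloro gives a number 16 percentage points lower from compound 1 to compound 4 (beyond the scatter), so in these two pairs a second ring substituent alongside a trifluoromethyl goes with a weaker effect, while compound 3, with its two chloro groups and no trifluoromethyl, goes against any reading that a second substituent alone weakens the effect. No measurement on hand accounts for these steps.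

Open, from the compounds shown here alone, is how a 3-chlorophenyl group, or an amine or a nitrile on this aryl ring, would read against compound 3 and compound 4 in this assay. Also open, going by these compounds, is whether compound 3 and compound 4 would remain indistinguishable at other concentrations, since a single-concentration read-out gives no potency.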